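A few compounds are considered here, and "the series" means these few. Any claim that something is new, unique, unknown or untested is made for them only; others in the source may bear on it.

Three compounds in this series already have numbers. Compound 1 `Nc1ncnc2[nH]cc(-c3ccc(NC(=O)c4cn(CC5CCOCC5)cc(-c5ccc(F)cc5)c4=O)cc3)c12` gives 0.2 nM in an assay on isolated protein for inhibition of tyrosine-protein kinase receptor UFO (Homo sapiens), read by ELISA; a higher number here means a weaker inhibitor, a lower number a stronger inhibitor. Compound 2 `Cn1cc(-c2ccc(NC(=O)c3cn(CC4CCCCC4)cc(-c4ccc(F)cc4)c3=O)cc2)c2c(N)ncnc21` gives 2.3 nM in this assay, and compound 3 `Cn1cc(-c2ccc(NC(=O)c3cn(CC4CCOCC4)cc(-c4ccc(F)cc4)c3=O)c(Cl)c2)c2c(N)ncnc21` gives 3.7 nM. Among these three, compound 2 has the second highest number; its nearest neighbour is compound 3, whose number lies within the usual scatter of it, while compound 1 sits well beyond the scatter with a markedly lower number.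

Compound 4 `CN(C)C(=O)Cn1cc(C(=O)Nc2ccc(-c3cn(C)c4ncnc(N)c34)cc2)c(=O)c(-c2ccc(F)cc2)c1` is not yet measured. It differs from compound 2 in one place: dimethylcarbamoyl in place of cyclohexyl on a saturated chain carbon bound to an aromatic nitrogen. Among the compounds with values here, no step between two measured compounds isolates this kind of exchange, so the expectation rests on the general level of the series. Compound 4 is expected to remain an active inhibitor in this assay, with a step from compound 2 to compound 4 a 2.2-fold higher number from compound 2 to compound 4 (0.34 log units; beyond the scatter) that is estimated to be small, most likely towards a somewhat higher number, and possibly not beyond the scatter. For compound 4 the estimate in this assay is 5 nM, within a range from 1.5 nM to 20 nM.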

Compound 4, half-maximal inhibitory concentration: 0.5 nM
Compound 4: middle estimate off by 10-fold (1.00 log units), on the high side, and the stated range ends above it.
By their numbers in this assay, from the lowest: compound 1; then compound 4; then compounds 2 and 3 (each within the scatter of the next).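

In this assay, exchanging cyclohexyl for dimethylcarbamoyl on a saturated chain carbon bound to an aromatic nitrogen gives a 4.6-fold lower number from compound 2 to compound 4 (0.66 log units; beyond the scatter), a modest change that lies beyond the scatter. Within the data shown here, this pair is the first to isolate an exchange at this position, and it shows that the six-membered carbon ring is not required there for strong inhibition: a group with no ring and with one hydrogen-bond acceptor gives the lower number. Nothing measured here accounts for the difference.

A single pair cannot show whether the lower number goes with the carbonyl, the two methyl groups on nitrogen or the absence of the ring. As far as these compounds go, how a carboxylic acid, a tertiary amine or a longer chain between the aromatic nitrogen and the carbonyl would behave at this place remains open.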